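Ring Size Swap on a Saturated Carbon: Compound 2 to Compound 3

This account rests on a few compounds, and the source may have more. Where it says the series, first, only, none or still open, it means among the compounds named here.

Of the compounds shown here, two have been tested in a functional assay on PC-3 cells (Homo sapiens) for antiproliferative activity, read by MTT assay, with a stated time of 96 h; a higher number here means a weaker inhibitor, a lower number a stronger inhibitor. Compound 1 `CCN1CCN(c2ccc3nnnc(Nc4cccc(OC(F)(F)F)c4)c3n2)CC1` gives 16900 nM in this assay. Compound 2 `FC(F)(F)Oc1cccc(Nc2nnnc3ccc(N4CCC(N5CCCCC5)CC4)nc23)c1` gives 5580 nM in this assay, the lower of the two numbers; the gap to compound 1 lies beyond the scatter of repeated measurements, so compound 2 is the stronger inhibitor of the pair.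

Compound 3 `FC(F)(F)Oc1cccc(Nc2nnnc3ccc(N4CCC(N5CCCC5)CC4)nc23)c1` has not been measured. It differs from compound 2 in one place: pyrrolidin-1-yl in place of piperidin-1-yl on a saturated ring carbon. The group that leaves and the group that enters are both saturated rings with a single nitrogen, without hydrogen-bond donors and with one hydrogen-bond acceptor each; the ring that enters is smaller by one carbon.

For the measured compounds named here, no measured pair shows what a change of this kind does here, so the step from compound 2 to compound 3 is expected to be small, as a 1.0-fold lower number from compound 2 to compound 3 (0.01 log units; within the scatter), within the scatter in either direction. Compound 3 is therefore estimated at 5500 nM in this assay, with a range from 2200 nM to 14000 nM.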

Compound 3, half-maximal inhibitory concentration: 8160 nM
Compound 3: middle estimate off by 1.5-fold (0.17 log units), on the low side, and the stated range covers the measured number.
By their numbers in this assay, from the lowest: compounds 2 and 3 (each within the scatter of the next); then compound 1.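

In this assay, taking one carbon out of the ring on the saturated carbon gives a 1.5-fold higher number from compound 2 to compound 3 (0.17 log units; within the scatter), so piperidin-1-yl and pyrrolidin-1-yl cannot be told apart at this position, and neither compound 2 nor compound 3 can be called the stronger. The other step, a 2.1-fold lower number from compound 1 to compound 3 (0.32 log units; beyond the scatter), lies beyond the scatter, though only modestly, and it shows that the lower number seen for compound 2 against compound 1 also appears with the smaller ring, so it does not depend on piperidin-1-yl alone. No measurement here explains either step, so these numbers describe what happens without saying why it happens.

From the compounds shown here alone, two rings that differ by one carbon cover very little ground, so it stays open whether a larger ring such as azepan-1-yl, a ring with a second hetero atom such as morpholin-4-yl, or an open-chain dimethylamino group on the same carbon would also stay within the scatter of compound 2. Whether a group of any of these kinds could bring the number much lower also remains unanswered.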